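Dropping the carbamoyl group: a small step from compound 2

A few compounds are considered here, and "the series" means these few. Any claim that something is new, unique, unknown or untested is made for them only; others in the source may bear on it.

Of the compounds shown here, three have been measured in an assay for inhibition of MAP kinase-interacting serine/threonine-protein kinase 2 (Homo sapiens), read by luminescence and ADP-Glo, with a stated time of 2 h; on this read-out lower numbers stand for stronger inhibition and higher numbers for weaker inhibition. Compound 1 `O=c1ccc(-c2ccc3cn[nH]c3c2)cn1Cc1ccccc1C(F)(F)F` gives 100 nM, compound 2 `NC(=O)c1cccc(Cn2cc(-c3ccc4cn[nH]c4c3)ccc2=O)c1` gives 106 nM, and compound 3 `O=c1ccc(-c2n[nH]c3ncc(Br)cc23)cn1Cc1ccccc1` gives 12 nM. Compound 2 has the highest of these three numbers; its number sits within the scatter of that of compound 1, while compound 3 shows a clearly lower number. Compound 4 `O=c1ccc(-c2ccc3cn[nH]c3c2)cn1Cc1ccccc1` has not been measured yet. It differs from compound 2 in one place: hydrogen in place of carbamoyl on an aromatic carbon. Since compound 1 and compound 2 carry different groups on the same ring yet give numbers within the scatter of each other, compound 4 is expected to stay close, with a step from compound 2 to compound 4 of a 1.4-fold higher number from compound 2 to compound 4 (0.15 log units; within the scatter). Compound 4 is therefore estimated at 150 nM, within a range from 50 nM to 450 nM.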

Compound 4, half-maximal inhibitory concentration: 75 nM
For compound 4 the middle estimate is 2.0-fold (0.30 log units) above the measured one; the range from low to high includes it.
By their numbers in this assay, from the lowest: compound 3; then compounds 4, 1 and 2 (each within the scatter of the next).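

Compound 4 carries neither group on this aromatic ring, yet both steps stay within the scatter: a 1.4-fold lower number from compound 2 to compound 4 (0.15 log units; within the scatter) and a 1.3-fold lower number from compound 1 to compound 4 (0.12 log units; within the scatter). Neither carbamoyl nor trifluoromethyl is therefore needed on this ring for a number of this size, and neither shows a measurable gain over hydrogen. No available measurement explains this result. Still open, going by these compounds, is whether an amine or a carboxylic acid on this ring would also stay within the scatter, and whether the same holds at the ring's other carbons.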